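Para-substituent swap on the shared core: cytotoxicity notes

The source may hold more compounds than are shown below. What is called first, only, known or untested is meant among the compounds shown, and "the series" means these compounds.

Measured so far:
compound 1 `O=C(O)CCC(=O)Nc1ccc(-c2nc3cc(C(F)(F)F)ccc3[nH]2)cc1` — > 100000 nM in this assay, a limit only
compound 2 `O=C(CN1CCCC1)Nc1ccc(-c2nc3cc(Cl)c(Cl)cc3[nH]2)cc1` — 8000 nM
compound 3 `O=[N+]([O-])c1ccc(-c2nc3cc(Cl)c(Cl)cc3[nH]2)cc1` — 17000 nM

In an ADME assay on MT4 cells (Homo sapiens) for cytotoxicity, read by MTT assay, with a stated time of 96 h (on this read-out higher numbers stand for lower toxicity in this test and lower numbers for higher toxicity in this test), compound 1 gives > 100000 nM. That value is a limit of the assay and not a number, so compound 1 stands at the limit of > 100000 nM in this assay, at which 1 of the 3 values shown sits, and its true position is not resolved. Within the data shown here, compound 2 gives 8000 nM and compound 3 gives 17000 nM; both are numbers rather than limits, and no step between them is computed here.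

Compound 4 `Fc1ccc(-c2nc3cc(C(F)(F)F)ccc3[nH]2)cc1` is not yet measured. It differs from compound 1 by fluoro in place of ((2-carboxyethyl)carbonyl)amino on an aromatic carbon. Among the measured compounds shown here, no measured step between two compounds isolates this change.

For compound 4 the expectation is a step from compound 1 toward lower numbers in this assay, larger than the scatter, though its size cannot be fixed because the value of compound 1 is a limit. The estimate for compound 4 is 30000 nM, with a range from 8000 nM to 100000 nM, a range chosen because compound 2 gives 8000 nM and compound 3 gives 17000 nM with other small groups in the same place. That estimate corresponds to an expected step of an at least 3.3-fold lower number from compound 1 to compound 4 (0.52 log units; beyond the scatter).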

Compound 4, half-maximal cytotoxic concentration: 22000 nM
Compound 4: middle estimate off by 1.4-fold (0.13 log units), on the high side; the measured number falls inside the stated range.
By their numbers in this assay, from the lowest: compound 2; then compounds 3 and 4 (each within the scatter of the next). At a limit, above all of these: compound 1.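

In this assay, fluoro in place of ((2-carboxyethyl)carbonyl)amino on an aromatic carbon, para to a large group, gives an at least 4.5-fold lower number from compound 1 to compound 4 (0.65 log units; beyond the scatter). Among these compounds, this is the first single change that can be read at this place, and it shows that the number in this assay moves beyond the scatter with the group there while the rest of the molecule stays fixed. Only a lower bound on the size of the step can be read, because compound 1 stands at a limit of the assay and not at a number: the limit of > 100000 nM in this assay, at which 1 of the 4 values shown sits.

Still open, as far as these compounds go, is which part of the change carries the step: the loss of the terminal carboxylic acid, the loss of the chain, or the entry of fluoro itself, and a plain amine or a methyl ester of the acid at this place on the core of compound 1 would begin to separate these. Compound 2 and compound 3 differ from compound 4 in more than one place, so they do not settle whether the same group swap would behave alike on their core.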